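From methyl to bromo on an aromatic ring

The source may hold more compounds than are shown below. What is called first, only, known or untested is meant among the compounds shown, and "the series" means these compounds.

Values from a functional assay on HepG2 cells (Homo sapiens) for inhibition, read by MTT assay, with a stated time of 72 h (on this read-out lower numbers stand for stronger inhibition and higher numbers for weaker inhibition), follow:
Compound 1 `Brc1ccc(-c2nnc(SCCCN3CCN(c4nc5ccccc5o4)CC3)o2)cc1` gives 67500 nM
Compound 2 `O=[N+]([O-])c1ccc(-c2nnc(SCCCN3CCN(c4nc5ccccc5s4)CC3)o2)cc1` gives 93300 nM
Compound 3 `Cc1ccc(-c2nnc(SCCCN3CCN(c4nc5ccccc5s4)CC3)o2)cc1` gives 96700 nM

The number for compound 3 lies within the scatter of both others, so it stands level with them. Compound 4 `Brc1ccc(-c2nnc(SCCCN3CCN(c4nc5ccccc5s4)CC3)o2)cc1` is compound 3 with bromo in place of methyl on an aromatic carbon, and bromo in place of methyl on an aromatic carbon sums up that change. For the measured compounds named here, one measured step touches that same carbon: a 1.0-fold higher number from compound 2 to compound 3 (0.02 log units; within the scatter) and it stayed within the scatter. Compound 1 also carries 4-bromophenyl, on a different core, and gives 67500 nM which is likewise within the scatter of the other two values. In this assay the expected step of a 1.1-fold lower number from compound 3 to compound 4 (0.06 log units; within the scatter) is therefore no larger than the scatter, with no direction foreseen. The estimate for compound 4 is 85000 nM with an expected range from 48000 nM to 150000 nM as its upper end.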

Compound 4, half-maximal inhibitory concentration: 103000 nM
For compound 4 the middle estimate is 1.2-fold (0.08 log units) below the measured one; measured number inside the range.
By their numbers in this assay, from the lowest: compounds 1, 2, 3 and 4 (each within the scatter of the next).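

In this assay, bromo in place of methyl gives a 1.1-fold higher number from compound 3 to compound 4 (0.03 log units; within the scatter) and bromo in place of nitro gives a 1.1-fold higher number from compound 2 to compound 4 (0.04 log units; within the scatter) at this carbon, so the three groups measured here stand level. With 4-bromophenyl kept, 1,3-benzothiazol-2-yl in place of 1,3-benzoxazol-2-yl gives a 1.5-fold higher number from compound 1 to compound 4 (0.18 log units; within the scatter) and likewise leaves the number level, showing that this second change also has no readable effect. No measured evidence offers an explanation for these results.

Still open, as far as these compounds go, is whether an amine, a carboxylic acid or a longer chain at this carbon would move the number beyond the scatter.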